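A few compounds are considered here, and "the series" means these few. Any claim that something is new, unique, unknown or untested is made for them only; others in the source may bear on it.

In an ADME assay on L1210/0 cells (Mus musculus) for cytotoxicity, with a stated time of 48 h (on this read-out lower numbers stand for stronger inhibition and higher numbers for weaker inhibition), compound 1 (`COc1ccccc1C(=O)/C=C/c1cc(=O)[nH]c(=O)n1COCCO`) reads 15200 nM and sits within the scatter of compound 3 (`CC(=O)OC(C)Cn1cnc2c(Cl)nc(I)nc21`) at 13000 nM on this read-out. Compound 2 (`CC(=O)OC(C)Cn1cnc2c(Cl)nc(F)nc21`) reads 37000 nM and stands apart from that pair. Compound 3 therefore shares the low end of the three numbers with compound 1.

The next structure is compound 4 (`CC(=O)OC(C)Cn1cnc2c(Cl)nc(N)nc21`), and the change is amino in place of iodo on an aromatic carbon with amino in place of iodo on an aromatic carbon, between two ring nitrogen atoms.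

Among the measured compounds shown here, only one measured step bears on this carbon: a 2.8-fold lower number from compound 2 to compound 3 (0.45 log units; beyond the scatter) with iodo in place of fluoro, a modest move beyond the scatter. For the measured compounds named here, it shows that a swap here can shift the number, but it is a single pair of halogens, and no amino compound has been measured. The direction is thus weakly supported. Losing the iodo of compound 3 is expected to move the number back toward that of compound 2 (37000 nM) by a modest amount at most.

The estimated step is a 1.9-fold higher number from compound 3 to compound 4 (0.28 log units; within the scatter) towards a higher number, although a result within the scatter would not be surprising. For compound 4 the expected value is 25000 nM with an estimated range from 9000 nM to 70000 nM as the working window.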

Compound 4, half-maximal inhibitory concentration: > 200000 nM
Compound 4: a limit, no number; the forecaster's own chance of this, stated with the estimate: 10%; middle value at least 8.0-fold (0.90 log units) from the limit.
By their numbers in this assay, from the lowest: compounds 3 and 1 (each within the scatter of the next); then compound 2. At a limit, above all of these: compound 4.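

Compound 4 reads > 200000 nM in this assay, and this is a limit of the assay, not a number. With amino on this aromatic carbon, between two ring nitrogen atoms, the readings are an at least 15-fold higher number from compound 3 to compound 4 (1.18 log units; beyond the scatter) and an at least 5.4-fold higher number from compound 2 to compound 4 (0.73 log units; beyond the scatter), so a swap here can move the number much further than the halogen pair alone showed, with a 2.8-fold lower number from compound 2 to compound 3 (0.45 log units; beyond the scatter). The two halogens at this carbon both give a readable number, while the amino group is the only one of the three substituents whose compound does not, and the series now has a single entry at the top of the measurable range: the limit of > 200000 nM in this assay, at which 1 of the 4 values shown sits.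

The real number of compound 4 stays unknown, so the steps to it fix only a minimum size, and the compounds shown cannot separate an effect of the amino group itself from that of losing a halogen. As far as these compounds go, how a bromo, methylamino or hydroxyl group on this carbon would read remains open, and so does whether the step holds when the chloro group or the acetate side chain on the shared core is changed.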